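The source may hold more compounds than are shown below. What is called first, only, known or untested is meant among the compounds shown, and "the series" means these compounds.

Values so far in an ADME assay on HEK293 cells (Homo sapiens) for cytotoxicity, with a stated time of 72 h; on this read-out higher numbers stand for an effect only at larger amounts of compound and lower numbers for an effect already at smaller amounts:
compound 1 (`Cc1cc(NC(=O)Nc2ccccc2OC(F)(F)F)c2ccccc2n1`) gives > 25000 nM as a limit of the assay
compound 2 (`CSc1ccc(NC(=O)Nc2cc(C)nc3ccccc23)cc1`) gives 24000 nM as a measured number
compound 3 (`Cc1cc(NC(=O)Nc2cccc([N+](=O)[O-])c2)c2ccccc2n1`) gives > 25000 nM as a limit of the assay

Among the measured compounds shown here, compound 2 at 24000 nM holds the only actual number in the set. The other two entries are limits. For the measured compounds named here, the overall picture is the limit of > 25000 nM in this assay, at which 2 of the 3 values shown sit, and no compound so far gives a number away from that region.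

The next compound is compound 4 (`Cc1ccc(NC(=O)Nc2cc(C)nc3ccccc23)cc1`), which has methyl in place of methylsulfanyl on an aromatic carbon, para to a large group (methyl in place of methylsulfanyl on an aromatic carbon). The rest of the structure is shared with compound 2.

Going by the values given here, no measured pair differs in one place only, so the series gives no direct size for this change. The expectation rests on compound 2 with its 24000 nM as the sole anchor. The expected step of a 1.0-fold higher number from compound 2 to compound 4 (0.02 log units; within the scatter) is none beyond the usual scatter, with no direction favoured. A report of compound 4 as a limit of the assay would also be no surprise. For compound 4 the estimate is 25000 nM (expected range 14000 nM to 40000 nM).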

Compound 4, half-maximal effective concentration: > 25000 nM
Compound 4 was reported as a limit; the forecaster's own chance of this, stated with the estimate: 60%; the middle value sits exactly at the limit.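

In this assay compound 4 gives > 25000 nM, which is a limit of the assay and not a number. Among the compounds shown here, this is the first pair that differs in one place, on an aromatic carbon para to a large group, and it gives an at least 1.0-fold higher number from compound 2 to compound 4 (0.01 log units; that floor lies within the scatter); that is only a floor on the step, and since it lies within the scatter, the exchange of methylsulfanyl for methyl shows no change that can be told from repeat variation, while a larger step is not excluded. With compound 4 added, the series sits even more firmly at one value: the limit of > 25000 nM in this assay, at which 3 of the 4 values shown sit.

As far as these compounds go, with only methylsulfanyl and methyl compared at this position, it remains open whether a different kind of group on the same aromatic carbon, such as an amine or a carboxylic acid, would give a number clearly away from the limit. From the compounds shown here alone, the true size of this step also stays open, as a number for compound 4 would be needed to read it.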